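Swapping a Sulfone Ring for an Acylated Piperazine

The compounds below may be only part of what the source reports. "The series", "measured", "known", "first", "only" and "open" are said of these compounds alone.

Measured so far:
Compound 1, `CC(C)(C)c1cc(NC(=O)[C@@H]2CCCCN2Cc2ccc(Cl)cc2)no1`: in a physicochemical assay for solubility, read by HPLC, at pH 6.8 (on this read-out lower numbers stand for lower solubility and higher numbers for higher solubility), compound 1 gives < 0.1 ug/mL, which is a limit of the assay rather than a number.
Compound 2, `CC(C)(C)c1cc(NC(=O)[C@@H]2CCCCN2C(=O)C2CCS(=O)(=O)CC2)no1`: in this assay compound 2 gives 67 ug/mL.

Among the measured compounds shown here, compound 2 therefore stands as the only real number among the two values shown; the other entry, for compound 1, sits at the limit of < 0.1 ug/mL in this assay, at which 1 of the 2 values shown sits. For the measured compounds named here, no step between compound 1 and compound 2 is computed here, and the two values show only that compound 2 dissolves measurably where compound 1 does not reach the range of the assay.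

The compound still to be measured is compound 3, `CCC(=O)N1CCN(C(=O)N2CCCC[C@H]2C(=O)Nc2cc(C(C)(C)C)on2)CC1`. Relative to compound 2 the change is 4-propanoylpiperazin-1-yl in place of 1,1-dioxothian-4-yl on a carbonyl carbon. Both the leaving group and the entering group are saturated six-membered rings carrying no charge and no hydrogen-bond donor, so in this assay the expected step is small: none beyond the usual scatter, with at most a slight lean in either direction.

On that basis compound 3 is estimated at 80 ug/mL, within a range of 20 ug/mL to 250 ug/mL, which corresponds to an expected step of a 1.2-fold higher number from compound 2 to compound 3 (0.08 log units; within the scatter).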

Compound 3, solubility: 68 ug/mL
For compound 3 the middle estimate is 1.2-fold (0.07 log units) above the measured one; the range from low to high includes it.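

At this carbonyl carbon, 1,1-dioxothian-4-yl and 4-propanoylpiperazin-1-yl cannot be told apart in this assay, and the result is a 1.0-fold higher number from compound 2 to compound 3 (0.01 log units; within the scatter). This is more than a matched reading between two similar groups: the entering group has more heavy atoms, replaces the sulfur with nitrogen, and adds a propanoyl chain, yet the two readings still lie within the scatter, so a measurable reading at this position does not depend on keeping the sulfone ring. Nothing shown here bears on why the two groups read alike.

This single step, made on one shared core, supports no general rule about what may sit at this position. On these data alone, it remains open how the reading would respond to groups with a different character, such as a piperazine with a free amine in place of the propanoyl group, a longer hexanoyl chain on the same ring, or a carboxylic acid on a six-membered ring, all attached at the same carbonyl carbon.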